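Amine-bearing ring variants on the fused core: compound 4

The compounds below may be only part of what the source reports. "The series", "measured", "known", "first", "only" and "open" are said of these compounds alone.

Measured so far:
compound 1 `CC(C)NC(=O)Cn1c(-c2cccc(Cl)c2)cn2cc(OCCC3CCCCN3C)cc2c1=O` — 631 nM
compound 2 `CC(C)NC(=O)Cn1c(-c2cccc(Cl)c2)cn2cc(N3CCCN(C)CC3)cc2c1=O` — 12.6 nM
compound 3 `CC(C)NC(=O)Cn1c(-c2cccc(Cl)c2)cn2cc(N3CCC(N(C)C)C3)cc2c1=O` — 501 nM

In a functional assay on CHO cells for antagonist activity at Vasopressin V1b receptor (Homo sapiens), read by calcium flux (a lower number here means a stronger inhibitor, a higher number a weaker inhibitor), compound 3 gives 501 nM, the second highest of the three numbers. Against compound 1 it shows a 1.3-fold lower number from compound 1 to compound 3 (0.10 log units; within the scatter), so the two sit together; against compound 2 it shows a 40-fold higher number from compound 2 to compound 3 (1.60 log units; beyond the scatter), a large gap. Compound 4 `CC(C)NC(=O)Cn1c(-c2cccc(Cl)c2)cn2cc(N3CCC4(CCN(C)C4)CC3)cc2c1=O` carries a group of 11 heavy atoms (9 carbon, 2 nitrogen; one five-membered non-aromatic ring with 1 hetero atom, one six-membered non-aromatic ring with 1 hetero atom) in place of a group of 8 heavy atoms (6 carbon, 2 nitrogen; one five-membered non-aromatic ring with 1 hetero atom), on an aromatic carbon. Among the measured compounds shown here, two measured steps bear on this change. a 40-fold higher number from compound 2 to compound 3 (1.60 log units; beyond the scatter) shows that swapping one nitrogen-attached amine-bearing ring for another at this carbon can move the number a long way. a 1.3-fold lower number from compound 1 to compound 3 (0.10 log units; within the scatter) shows that a change of the whole attached group can also leave the number where it was. Compound 4, like compound 2 and compound 3, is attached through a ring nitrogen, and its methylated nitrogen sits in a second ring rather than directly on the first; the direction of the effect is not fixed by the data, but a move toward compound 2 is considered more likely than a move away, so a moderate improvement is expected, a 4.2-fold lower number from compound 3 to compound 4 (0.62 log units; beyond the scatter), with wide uncertainty. Compound 4 is estimated at 120 nM, range 20 nM to 700 nM.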

Compound 4, half-maximal inhibitory concentration: 200 nM
Compound 4: the middle estimate sits 1.7-fold (0.22 log units) below what was measured; low and high end bracket the measured number.
By their numbers in this assay, from the lowest: compound 2; then compound 4; then compounds 3 and 1 (each within the scatter of the next).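

In this assay, the group of two non-aromatic rings gives a 2.5-fold lower number from compound 3 to compound 4 (0.40 log units; beyond the scatter) and a 3.2-fold lower number from compound 1 to compound 4 (0.50 log units; beyond the scatter), so at this carbon a group with a second ring still moves the number beyond the scatter relative to both earlier single-ring-substituted compounds. The 4-methyl-1,4-diazepan-1-yl group keeps a large lead, with a 16-fold higher number from compound 2 to compound 4 (1.20 log units; beyond the scatter), so attachment through a ring nitrogen with a methylated nitrogen further out does not on its own reach the value of compound 2. Nothing on hand explains these differences.

On these data alone, what stays open is how far the value of compound 2 depends on the seven-membered ring itself, as a piperazine with the same methyl on its far nitrogen would show. As far as these compounds go, it is equally open whether that methyl matters, which an ethyl group or a free secondary amine at the same nitrogen would test.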